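From Compound 1 to Compound 4: a Ring Swap at the Carbonyl

The source may report more compounds than this note shows. Statements on the series, on what has been measured and on what is new or still open speak of the compounds shown alone.

Three compounds have been measured in an ADME assay on L929 cells (Mus musculus) for cytotoxicity, read by resazurin assay, with a stated time of 72 h; a higher number here means a weaker inhibitor, a lower number a stronger inhibitor:
compound 1, `Cc1cccc(C(=O)/C=C/c2ccc3c(c2)B(O)OC3)c1`: 8.56 ug/mL
compound 2, `COc1cc(C(=O)/C=C/c2ccc3c(c2)B(O)OC3)ccc1[N+](=O)[O-]`: > 10 ug/mL, which is a limit of the assay rather than a number
compound 3, `COc1cc(C(=O)/C=C/c2ccc3c(c2)B(O)OC3)ccc1N`: 1.45 ug/mL

Of the two numbers, compound 1 holds the higher one; compound 3 sits lower by more than the scatter. For the measured compounds named here, the single step measured in one place is an at least 6.8-fold lower number from compound 2 to compound 3 (0.83 log units; beyond the scatter). Compound 2 sits at the limit of > 10 ug/mL in this assay, at which 1 of the 3 values shown sits. Compound 4, `O=C(/C=C/c1ccc2c(c1)B(O)OC2)c1ccc(F)cc1`, differs from compound 1 elsewhere: 4-fluorophenyl in place of 3-methylphenyl on a carbonyl carbon. Going by the values given here, no measured step touches a group on the carbonyl carbon, so no step beyond the scatter is expected, the estimated step being a 1.1-fold lower number from compound 1 to compound 4 (0.03 log units; within the scatter). For compound 4 the estimate in this assay is 8 ug/mL, with a range from 4 ug/mL to 16 ug/mL.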

Compound 4, half-maximal inhibitory concentration: > 10 ug/mL
Compound 4: no number, only a limit; the forecaster's own chance of this, stated with the estimate: 35%; middle value at least 1.2-fold (0.09 log units) from the limit.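

For the compounds shown here, this is the first measured step at the carbonyl carbon: with 4-fluorophenyl in place of 3-methylphenyl, this assay shows an at least 1.1-fold higher number from compound 1 to compound 4 (0.06 log units; that floor lies within the scatter). Compound 4 yields a limit rather than a number, so that step is only a floor and its true size cannot be read. The swap therefore shows no lower number at this position, and the assay ceiling now covers more of the series: the limit of > 10 ug/mL in this assay, at which 2 of the 4 values shown sit.

On these data alone, how far compound 4 lies past that limit remains open. So does whether a carboxylic acid on the ring at the carbonyl carbon would bring the number down.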